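The source may report more compounds than this note shows. Statements on the series, on what has been measured and on what is new or still open speak of the compounds shown alone.

Compound 1 `CN(C)C(=O)/C=C1\CCc2ccc(F)cc21` and compound 2 `CN(C)C(=O)/C=C1\CCc2c(F)cc(F)cc21` share one core, while compound 3 `O=C(/C=C1\CCc2c(F)cccc21)NC1CC1` and compound 4 `O=C(/C=C1\CCc2c1ccc(F)c2F)NC1CC1` share another; how the two cores differ is not broken down here. All were examined in a functional assay on the whole organism with Mus musculus as the target; a lower number here means that less compound is needed, a higher number that more compound is needed for the effect. Compound 1 reaches only the limit of the assay, > 100 mg/kg, not a number. Compound 2 gives 50 mg/kg, and compound 3 gives 126 mg/kg. The change from compound 1 to compound 2, (fluoro in place of hydrogen on an aromatic carbon), brought an at least 2.0-fold lower number from compound 1 to compound 2 (0.30 log units; that floor lies within the scatter); the step is stated only as a floor because of the limit of > 100 mg/kg in this assay, at which 1 of the 3 values shown sits. The change from compound 3 to compound 4, (fluoro in place of hydrogen on an aromatic carbon), is the same kind of change, yet its place differs: in compound 4 the fluoro enters ortho to a fluoro group, meta to a fused ring and para to a fused ring, whereas in compound 2 it entered ortho to a fused ring, meta to a fluoro group and meta to a fused ring. Resting on the step from compound 1 to compound 2, an at least 2.0-fold lower number from compound 1 to compound 2 (0.30 log units; that floor lies within the scatter), a step of a 2.1-fold lower number from compound 3 to compound 4 (0.32 log units; beyond the scatter) is expected in this assay. Compound 4 is thus estimated at 60 mg/kg, with a range from 25 mg/kg to 150 mg/kg.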

Compound 4, dose for half-maximal effect: 62 mg/kg
Beside the measured number, compound 4's estimate is 1.0-fold (0.01 log units) below it; the measured number falls inside the stated range.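

In this assay, fluoro in place of hydrogen on an aromatic carbon brought a 2.0-fold lower number from compound 3 to compound 4 (0.31 log units; beyond the scatter), a modest step that is beyond the usual scatter. Set beside the earlier case, the same change goes with a lower number on both cores, but the sizes of the two steps cannot be told apart: the same change on two cores in this assay, an at least 2.0-fold lower number (0.30 log units; that floor lies within the scatter) from compound 1 to compound 2 and a 2.0-fold lower number (0.31 log units; beyond the scatter) from compound 3 to compound 4; the limit leaves it open whether they differ. This gives two pairs in which the direction holds, with the fluoro entering at a different place in each, and it does not show that the size of the step carries over from one core to the other or that the direction would hold on a further core.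

The compounds shown leave open how other groups, such as chloro, methoxy or a nitrile, would behave on the same aromatic carbon. They also leave open whether the step would persist if the cyclopropyl group on the amide of compound 4 gave way to a longer chain or a chain bearing an amine.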